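The compounds below may be only part of what the source reports. "The series", "measured", "known", "first", "only" and "open" are said of these compounds alone.

Measured so far in a functional assay on aorta (Rattus norvegicus, strain Wistar) for inhibition; on this read-out higher numbers stand for an effect only at larger amounts of compound and lower numbers for an effect already at smaller amounts:

- compound 1, `Cn1c(=O)c2ccccc2c(=O)n1CCCNC(=O)OC(C)(C)C`: 23600 nM
- compound 2, `Cn1c(=O)c2cccc(Cl)c2c(=O)n1CCCNC(=O)OC(C)(C)C`: 18200 nM
- compound 3, `Cn1c(=O)c2ccccc2c(=O)n1CCN=[N+]=[N-]`: 15900 nM

Compound 1 and compound 2 differ in one place: chloro in place of hydrogen on an aromatic carbon. This change gave a 1.3-fold lower number from compound 1 to compound 2 (0.11 log units; within the scatter). Compound 3 carries a different side chain on the shared core; how its core differs from that of compound 1 is not broken down here, and the values of compound 1 and compound 3 lie within the scatter of each other.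

The unmeasured compound 4, `Cn1c(=O)c2cccc(Cl)c2c(=O)n1CCN=[N+]=[N-]`, is related to compound 3 in the same way: chloro in place of hydrogen on an aromatic carbon. Both place lines read the same, so this is the same change. Since compound 2 sits close to compound 1 in this assay, the step from compound 3 to compound 4 is expected to be small as well, estimated at a 1.3-fold lower number from compound 3 to compound 4 (0.10 log units; within the scatter). Compound 4 is therefore expected to give about 12500 nM, plausibly between 6000 nM and 25000 nM.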

Compound 4, half-maximal effective concentration: 13200 nM
For compound 4 the middle estimate is 1.1-fold (0.02 log units) below the measured one, and the stated range covers the measured number.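

In this assay, chloro in place of hydrogen on an aromatic carbon gave a 1.2-fold lower number from compound 3 to compound 4 (0.08 log units; within the scatter) and so made no clear difference on this second core. Among the compounds shown here, the two steps agree, so the change carried over from one core to the other without a detectable shift: the same change on two cores in this assay, a 1.3-fold lower number (0.11 log units; within the scatter) from compound 1 to compound 2 and a 1.2-fold lower number (0.08 log units; within the scatter) from compound 3 to compound 4, 1.1-fold (0.03 log units) apart, within the scatter of two such steps Neither step stands clear of the scatter, however, so this shows only that a small step repeated on these two cores, not that chloro has a real effect or would behave alike on any other core.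

The compounds shown leave open whether bromo or methoxy at that same place would give a clear step. They also leave open whether chloro would still give so small a step with an amine or a carboxylic acid at the end of the side chain.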